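Aryl Amine Swap on a Shared Core, Inhibition Near Zero

This account rests on a few compounds, and the source may have more. Where it says the series, first, only, none or still open, it means among the compounds named here.

Measured compounds:
compound 1, `Cc1n[nH]c2ccc(-c3nc4cnc(N5CCN(C)CC5)cn4c3Nc3ccccc3F)cc12`, 0% 
compound 2, `Cc1n[nH]c2ccc(-c3nc4cnc(N5CCN(C)CC5)cn4c3Nc3ccccc3Cl)cc12`, "not determined" (no result reported) 
compound 3, `Cc1n[nH]c2ccc(-c3nc4cnc(N5CCN(C)CC5)cn4c3Nc3ccc(F)cc3Br)cc12`, 4.41% 

Going by the values given here, compound 1 stands lowest of the two numbers in a functional assay on CWR22R cells (Homo sapiens) for inhibition, with a stated time of 120 h, tested at 10 uM (on this read-out higher numbers stand for more inhibition at the one concentration tested (going by the name of the read-out) and lower numbers for less inhibition), though its only neighbour sits within the scatter: the step of a number 4.4 percentage points higher from compound 1 to compound 3 (within the scatter) brings 2-bromo-4-fluorophenyl in place of 2-fluorophenyl on a nitrogen on an aromatic ring and changes nothing of note. Compound 4, `Cc1n[nH]c2ccc(-c3nc4cnc(N5CCN(C)CC5)cn4c3Nc3ccc(F)c(Cl)c3)cc12`, is not yet measured; it differs from compound 1 by 3-chloro-4-fluorophenyl in place of 2-fluorophenyl on a nitrogen on an aromatic ring. Among the compounds with values here, only that one step speaks to a change of the aryl group on this nitrogen, and it stayed flat, so no movement beyond the scatter is expected. For compound 4 in this assay the estimate is 3%, between 0% and 15%, the expected step being a number 3 percentage points higher from compound 1 to compound 4 (within the scatter).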

Compound 4, a percentage reported as inhibition, at one concentration (the size of the read-out at that concentration, not a potency): 0.82%
The estimate for compound 4 lay 2.2 percentage points above the measured number; measured number inside the range.
By their numbers in this assay, from the lowest: compounds 1, 4 and 3 (each within the scatter of the next).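

With 3-chloro-4-fluorophenyl on this nitrogen, this assay shows a number 0.8 percentage points higher from compound 1 to compound 4 (within the scatter) and a number 3.6 percentage points lower from compound 3 to compound 4 (within the scatter), so a third halogen pattern on the phenyl ring also brings no change beyond the scatter. Compounds 1, 3 and 4 therefore read alike, and the added chlorine of compound 4 does not separate it from either neighbour. No supporting evidence bears on this flat result.

From the compounds shown here alone, it remains open whether a phenyl ring carrying an amine or a carboxylic acid would give a different read-out at this nitrogen. The same question stands for a longer chain in place of the ring.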